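The source may hold more compounds than are shown below. What is called first, only, known or untested is meant among the compounds shown, and "the series" means these compounds.

In a functional assay on A549 cells (Homo sapiens) for cytotoxicity, read by MTT assay, with a stated time of 72 h (a higher number here means a weaker inhibitor, a lower number a stronger inhibitor), compound 3 (`O=C(/C=C/c1ccccc1[N+](=O)[O-])Nc1cc2c(Nc3ccc(F)c(Cl)c3)ncnc2cc1O[C@H]1CCOC1`) gives 8820 nM, the middle of the three measured values. Compound 1 (`O=C(/C=C/c1cccc(Cl)c1Cl)Nc1cc2c(Nc3ccc(F)c(Cl)c3)ncnc2cc1O[C@H]1CCOC1`) gives 23200 nM, and compound 2 (`COc1cc(/C=C/C(=O)Nc2cc3c(Nc4ccc(F)c(Cl)c4)ncnc3cc2O[C@H]2CCOC2)cc(OC)c1OC`) gives 4150 nM. Compound 4 (`COc1cc(/C=C/C(=O)Nc2cc3c(Nc4ccc(F)c(Cl)c4)ncnc3cc2O[C@H]2CCOC2)cc(OC)c1`) differs from compound 3 by one change: 3,5-dimethoxyphenyl in place of 2-nitrophenyl on a double-bonded chain carbon bound to a double-bonded chain carbon. Three measured swaps of this same group bear on it, and all are modest: a 5.6-fold lower number from compound 1 to compound 2 (0.75 log units; beyond the scatter), a 2.6-fold lower number from compound 1 to compound 3 (0.42 log units; beyond the scatter) and a 2.1-fold higher number from compound 2 to compound 3 (0.33 log units; beyond the scatter). The incoming 3,5-dimethoxyphenyl most resembles the 3,4,5-trimethoxyphenyl of compound 2, which gives 4150 nM, so a value near that one seems likely. The expected change is small and toward a lower number, not beyond the scatter: a 1.8-fold lower number from compound 3 to compound 4 (0.25 log units; within the scatter). For compound 4 the estimated value is 5000 nM, with an expected range of 2300 nM to 11000 nM.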

Compound 4, half-maximal inhibitory concentration: 10800 nM
Beside the measured number, compound 4's estimate is 2.2-fold (0.33 log units) below it; the measured number falls inside the stated range.
By their numbers in this assay, from the lowest: compound 2; then compounds 3 and 4 (each within the scatter of the next); then compound 1.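

In this assay, 3,5-dimethoxyphenyl and 2-nitrophenyl cannot be told apart at this position, with a 1.2-fold higher number from compound 3 to compound 4 (0.09 log units; within the scatter), although the two groups share little beyond the ring. The third methoxy group of compound 2 does matter, since hydrogen in its place gives a 2.6-fold higher number from compound 2 to compound 4 (0.42 log units; beyond the scatter), while 3,5-dimethoxyphenyl still keeps a measurable edge over 2,3-dichlorophenyl, with a 2.1-fold lower number from compound 1 to compound 4 (0.33 log units; beyond the scatter).

Nothing shown explains why these differences arise. Also open, on these data alone, is how an amine or a carboxylic acid on this ring would compare, or a single methoxy group.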